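The source may hold more compounds than are shown below. What is called first, only, known or untested is meant among the compounds shown, and "the series" means these compounds.

Four compounds belong to this account. Compound 1 `CCCCC(=O)NCCCc1ccccc1OC` was tested in an assay for binding affinity to melatonin receptor (Gallus gallus); a higher number here means a weaker inhibitor, a lower number a stronger inhibitor; the result for compound 1 is a limit of the assay and not a number, > 100000 nM. Compound 2 `COc1cccc(CCCNC(C)=O)c1` gives 63 nM in this assay. Compound 3 `COc1ccc(CCCNC(C)=O)cc1` gives 14000 nM in this assay, the highest of the two numbers on record; the figure for compound 2 lies far below it, well beyond the usual scatter. Compound 4 `CCC(=O)NCCCc1ccc(OC)cc1` has not yet been measured in this assay. It differs from compound 3 in one place, (methyl in place of hydrogen on a saturated chain carbon bound to a carbonyl carbon), so that the acetyl becomes a propanoyl. Going by the values given here, no pair among the measured compounds differs in this single place, so no measured step can guide the expectation. A small step, at the edge of the scatter and towards a lower number, is expected a 2.0-fold lower number from compound 3 to compound 4 (0.30 log units; within the scatter). Compound 4 is therefore estimated at 7000 nM, with a range from 2000 nM to 30000 nM.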

Compound 4, inhibition constant: 2900 nM
For compound 4 the middle estimate is 2.4-fold (0.38 log units) above the measured one; measured number inside the range.
By their numbers in this assay, from the lowest: compound 2; then compound 4; then compound 3. At a limit, above all of these: compound 1.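

In this assay the acyl side of the amide now has its first measured change: methyl in place of hydrogen on a saturated chain carbon bound to a carbonyl carbon gives a 4.8-fold lower number from compound 3 to compound 4 (0.68 log units; beyond the scatter). The acetyl can thus become a propanoyl on this core without loss, and the added methyl brings a modest gain rather than a mere shift within the scatter. The record holds nothing that explains this step.

This single pair cannot show whether a longer chain, such as butanoyl, or a branched one, such as isobutanoyl, would extend the gain or reverse it. It also leaves open whether propanoyl in place of acetyl would give a step of like size on compound 2, with its methoxy group placed differently.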